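This account rests on a few compounds, and the source may have more. Where it says the series, first, only, none or still open, it means among the compounds named here.

Working notes on the series. Compound 1 `ClCc1ccccc1Cn1cnc2c(Cl)nc(Cl)nc21`, compound 2 `ClCc1ccccc1Cn1cnc2c(Cl)ncnc21` and compound 3 `ClCc1cccc(Cn2cnc3ncnc(Cl)c32)c1` have been run in a functional assay on A498 cells (Homo sapiens) for cytotoxicity, read by sulforhodamine B assay, with a stated time of 48 h; on this read-out lower numbers stand for stronger inhibition of growth and higher numbers for weaker inhibition of growth. Compound 1 gives 4780 nM, compound 2 gives 32400 nM, and compound 3 gives 36300 nM. Among the compounds with values here, the single change from compound 2 to compound 1 is chloro in place of hydrogen on an aromatic carbon, and it produced a 6.8-fold lower number from compound 2 to compound 1 (0.83 log units; beyond the scatter). Compound 2 and compound 3 are built from the same atoms joined differently; the difference between their cores is not broken down here, and their two values lie within the usual scatter of one another, so no order between them is claimed. Compound 4 `ClCc1cccc(Cn2cnc3nc(Cl)nc(Cl)c32)c1` has not yet been measured in this assay. It differs from compound 3 by chloro in place of hydrogen on an aromatic carbon, the same change as that from compound 2 to compound 1, placed in exactly the same surroundings. Within the data shown here, the expected step from compound 3 to compound 4 is a 6.6-fold lower number from compound 3 to compound 4 (0.82 log units; beyond the scatter), set beside the earlier one, and rests on the step seen from compound 2 to compound 1, a 6.8-fold lower number from compound 2 to compound 1 (0.83 log units; beyond the scatter), the only precedent for this change. Compound 4 is therefore estimated at 5500 nM, with an expected range from 2000 nM to 15000 nM.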

Compound 4, concentration for total growth inhibition: 2810 nM
Compound 4: middle estimate off by 2.0-fold (0.29 log units), on the high side; the range from low to high includes it.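

In this assay, chloro in place of hydrogen on the aromatic carbon between two ring nitrogen atoms gives a 13-fold lower number from compound 3 to compound 4 (1.11 log units; beyond the scatter), a large step in the same direction as the earlier one. Set beside that earlier step, the change carries across the two cores with no difference that can be told apart, so no order between the two steps is claimed: the same change on two cores in this assay, a 6.8-fold lower number (0.83 log units; beyond the scatter) from compound 2 to compound 1 and a 13-fold lower number (1.11 log units; beyond the scatter) from compound 3 to compound 4, 1.9-fold (0.28 log units) apart, within the scatter of two such steps. Within the data shown here, this rests on only two pairs of compounds, so it shows that the step held on the cores of compound 2 and compound 3, but it does not establish a general rule for other cores and gives no explanation for the step.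

The compounds shown leave open whether an amine or a methoxy group on that same carbon would give a step like that of chloro. They also leave open whether the step would persist if a hydroxymethyl group took the place of the chloromethyl group.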